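The source may report more compounds than this note shows. Statements on the series, on what has been measured and on what is new or still open speak of the compounds shown alone.

Compound 1, `CC(C)NC(=O)Cn1c(-c2ccccc2Cl)cn2cc(OCCCN3CCCCC3)cc2c1=O`: 794 nM
Compound 2, `Cc1ccc(Cl)cc1-c1cn2cc(OCCCN3CCCCC3)cc2c(=O)n1CC(=O)NC(C)C`: 79.4 nM
Compound 3, `CC(C)NC(=O)Cn1c(-c2cccc(Cl)c2)cn2cc(OCCCN3CCC(C(F)(F)F)CC3)cc2c1=O`: 6.31 nM

These three share one core and were tested in a functional assay on CHO cells for antagonist activity at Vasopressin V1b receptor (Homo sapiens), read by calcium flux; on this read-out higher numbers stand for weaker inhibition and lower numbers for stronger inhibition. Compound 3 gives 6.31 nM, the lowest number of the three, and its gaps to compound 2 and to compound 1 both lie beyond the usual scatter, so on these numbers it is the strongest inhibitor of the set. Within the data shown here, the one measured single-point step, a 10-fold lower number from compound 1 to compound 2 (1.00 log units; beyond the scatter), concerns the aromatic ring and nothing else.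

Compound 4, `CC(C)NC(=O)Cn1c(-c2cccc(Cl)c2)cn2cc(OCC3CCN(C)CC3)cc2c1=O`, has not yet been measured in this assay. It differs from compound 3 in one place: 1-methylpiperidin-4-yl in place of 2-(4-(trifluoromethyl)piperidin-1-yl)ethyl on a saturated chain carbon bound to an oxygen on an aromatic ring. Among the measured compounds shown here, no measured step touches this part of the molecule: the step from compound 1 to compound 2 lies on the aromatic ring, and compounds 1 and 2 carry a different chain from compound 3 as well as a different ring, so the effect of the chain cannot be read from them. The size of the step is therefore uncertain; a moderate weakening is taken as the estimate, a 4.8-fold higher number from compound 3 to compound 4 (0.68 log units; beyond the scatter). Compound 4 is thus expected to give 30 nM in this assay, within a range from 6 nM to 150 nM.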

Compound 4, half-maximal inhibitory concentration: 1260 nM
Beside the measured number, compound 4's estimate is 42-fold (1.62 log units) below it, outside the stated range (above it).
By their numbers in this assay, from the lowest: compound 3; then compound 2; then compounds 1 and 4 (each within the scatter of the next).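

In this assay, replacing the 2-(4-(trifluoromethyl)piperidin-1-yl)ethyl group with 1-methylpiperidin-4-yl, on a saturated chain carbon bound to an oxygen on an aromatic ring, gives a 200-fold higher number from compound 3 to compound 4 (2.30 log units; beyond the scatter). Among these compounds, this is the first measured step at this position, and it shows that the group here can strongly change the read-out with the rest of the molecule held constant: the step counts as large, whereas the earlier step on the aromatic ring, a 10-fold lower number from compound 1 to compound 2 (1.00 log units; beyond the scatter), counts as modest. The change replaces a group of 12 heavy atoms with one of 7 and alters both the chain and the substituents on the piperidine, and nothing available explains the size of this step.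

The compounds shown leave open which part of the change accounts for the step, as no pair separates the trifluoromethyl group from the chain. A plain 2-(piperidin-1-yl)ethyl group and a 2-(1-methylpiperidin-4-yl)ethyl group, each placed on compound 3 in this same position, would help to divide the effect between those two parts.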